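The source may report more compounds than this note shows. Statements on the series, on what has been measured and on what is new or still open speak of the compounds shown alone.

Three compounds have so far been measured in a functional assay on PC-12 cells (Rattus norvegicus) for inhibition, read by MTT assay; a lower number here means that less compound is needed, a higher number that more compound is needed for the effect:

Compound 1 `COC(=O)[C@@H](N)CC(=O)NCCOc1ccc(C2=[N+]([O-])C(C)(C)C(C)(C)N2O)cc1`: 55600 nM
Compound 2 `CC(C)(C)OC(=O)N[C@@H](CCC(=O)NCCOc1ccc(C2=[N+]([O-])C(C)(C)C(C)(C)N2O)cc1)C(=O)O`: 59000 nM
Compound 3 `CC1(C)N(O)C(c2ccc(OCCNC(=O)CC[C@H](N)C(=O)O)cc2)=[N+]([O-])C1(C)C`: 58100 nM

Compound 3 sits among numbers that cannot be told apart: the step of a 1.0-fold higher number from compound 1 to compound 3 (0.02 log units; within the scatter) and the step of a 1.0-fold lower number from compound 2 to compound 3 (0.01 log units; within the scatter) both lie within the scatter, so the three measured compounds give, in effect, one value.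

Compound 4 `CC1(C)N(O)C(c2ccc(OCCNC(=O)CC[C@H](N)C(=O)N[C@H](CS)C(=O)NCC(=O)O)cc2)=[N+]([O-])C1(C)C` differs from compound 3 by (1-((carboxymethyl)carbamoyl)-2-sulfanylethyl)amino in place of hydroxy on a carbonyl carbon. The two measured steps that bear on this change both alter the same amino-acid end of the chain, one at the carboxyl side and one at the amine nitrogen, and neither moved the number: a 1.0-fold higher number from compound 1 to compound 3 (0.02 log units; within the scatter) and a 1.0-fold lower number from compound 2 to compound 3 (0.01 log units; within the scatter). On that basis the extension of the carbonyl carbon in compound 4 is expected to leave the number where it is, with no step beyond the scatter in either direction, so that a 1.0-fold lower number from compound 3 to compound 4 (0.00 log units; within the scatter) is the expected change. Compound 4 is therefore estimated at 58000 nM, with a range from 29000 nM to 116000 nM.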

Compound 4, half-maximal effective concentration: 54900 nM
Compound 4: the middle estimate sits 1.1-fold (0.02 log units) above what was measured; low and high end bracket the measured number.
By their numbers in this assay, from the lowest: compounds 4, 1, 3 and 2 (each within the scatter of the next).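

In this assay, replacing hydroxy with (1-((carboxymethyl)carbamoyl)-2-sulfanylethyl)amino on this carbonyl carbon gives a 1.1-fold lower number from compound 3 to compound 4 (0.02 log units; within the scatter), so even here, where 11 heavy atoms enter in place of 1, among them a sulfur and a defined stereocentre, the step stays within the scatter. The carbonyl carbon itself therefore joins the other altered sites at this end of the chain, and the four compounds still give, in effect, one value. Nothing available accounts for this result.

The compounds shown leave open whether any group on this carbonyl carbon, such as a simple amine, a phenyl group or a longer alkyl chain, would give a step beyond the scatter. They also leave open what part the sulfanylethyl and carboxymethyl pieces play separately, and whether changes to the shared core would move the number.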